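This account rests on a few compounds, and the source may have more. Where it says the series, first, only, none or still open, it means among the compounds named here.

Measured compounds and their numbers in an assay (Cricetulus griseus) for inhibition of aldehyde dehydrogenase, mitochondrial (Homo sapiens); a higher number here means a weaker inhibitor, a lower number a stronger inhibitor:
compound 1 `CCOC(=O)CCCCCOc1ccc2c(=O)c(-c3ccc(O)cc3)coc2c1`: 280 nM
compound 2 `O=C(O)CCCCCCCOc1ccc2c(=O)c(-c3ccc(O)cc3)coc2c1`: 40 nM
compound 3 `NCCCCOc1ccc2c(=O)c(-c3ccc(O)cc3)coc2c1`: 250 nM

Compound 3 stands second highest of the three numbers. Its nearest neighbour is compound 1, the difference being within the scatter, as the step of a 1.1-fold lower number from compound 1 to compound 3 (0.05 log units; within the scatter) shows. Compound 2 is furthest away, with the step of a 6.3-fold higher number from compound 2 to compound 3 (0.80 log units; beyond the scatter) lying beyond the scatter.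

Compound 4 `O=c1c(-c2ccc(O)cc2)coc2cc(OCCCCCCO)ccc12` differs from compound 3 as follows: 2-hydroxyethyl in place of amino on a saturated chain carbon, four bonds along the chain from an oxygen on an aromatic ring. Among the compounds with values here, two measured steps bear on this change, since both alter the group on the same saturated chain carbon. The step of a 1.1-fold lower number from compound 1 to compound 3 (0.05 log units; within the scatter) was within the scatter, whereas the step of a 6.3-fold higher number from compound 2 to compound 3 (0.80 log units; beyond the scatter) was modest and beyond it. Within the data shown here, no measured step involves a hydroxyl group. Because the chain carrying a longer end group with one hydrogen-bond donor gave the lowest number in a 6.3-fold higher number from compound 2 to compound 3 (0.80 log units; beyond the scatter), a somewhat lower number is expected for compound 4. The expected shift for compound 4 is smaller than that one, estimated as a 1.7-fold lower number from compound 3 to compound 4 (0.22 log units; within the scatter). Compound 4 is therefore estimated at 150 nM, within the range 50 nM to 450 nM.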

Compound 4, half-maximal inhibitory concentration: 120 nM
Estimate against measurement, compound 4: 1.3-fold (0.10 log units) above, within the range that was stated.
By their numbers in this assay, from the lowest: compound 2; then compound 4; then compounds 3 and 1 (each within the scatter of the next).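

In this assay, replacing the amino end group with a longer chain ending in hydroxyl gives a change beyond the scatter (a 2.1-fold lower number from compound 3 to compound 4 (0.32 log units; beyond the scatter)), whereas compound 1 and compound 3 could not be told apart. Compound 4 is also separated from the ethoxycarbonyl chain (a 2.3-fold lower number from compound 1 to compound 4 (0.37 log units; beyond the scatter)), yet the carboxylic acid chain keeps the lowest number (a 3.0-fold higher number from compound 2 to compound 4 (0.48 log units; beyond the scatter)), so a hydroxyl end group places compound 4 second lowest of the four, with its steps to all three others beyond the scatter. No measurement given here explains any of these steps.

The step from compound 3 to compound 4 changes the end group and the chain length together, so their shares remain unseparated. An amine on the longer chain of compound 4, or a hydroxyl on the shorter chain of compound 3, would divide the two.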